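This account rests on a few compounds, and the source may have more. Where it says the series, first, only, none or still open, it means among the compounds named here.

Compound 1, `COc1ccc(Cl)cc1S(=O)(=O)Nc1cncc(C(N)=O)c1`: 16 nM
Compound 2, `COc1ccc(Br)cc1S(=O)(=O)Nc1cncc(C(N)=O)c1`: 14 nM
Compound 3, `COc1ccc(F)cc1S(=O)(=O)Nc1cncc(C(N)=O)c1`: 19 nM

These three compounds share one core and differ only in which halogen sits on the aromatic carbon of the methoxy-bearing ring. All were tested in an assay on isolated protein for inhibition of alkaline phosphatase, tissue-nonspecific isozyme (Homo sapiens); a lower number here means a stronger inhibitor, a higher number a weaker inhibitor. Compound 1 stands second highest of the three numbers; its nearest neighbour is compound 2, with a 1.1-fold lower number from compound 1 to compound 2 (0.06 log units; within the scatter), and its furthest is compound 3, with a 1.2-fold higher number from compound 1 to compound 3 (0.07 log units; within the scatter). The remaining pair, a 1.4-fold higher number from compound 2 to compound 3 (0.13 log units; within the scatter), is likewise within the scatter, so the three halogens cannot be told apart on these numbers.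

Compound 4, `COc1ccc(Cl)cc1S(=O)(=O)Nc1cncc(-c2cccc(C)c2)c1`, has not yet been measured. It differs from compound 1 in one place: 3-methylphenyl in place of carbamoyl on an aromatic carbon. Within the data shown here, none of the measured steps bears on this change: each of them exchanges one halogen for another on the other ring, while here a carbamoyl, with its one hydrogen-bond donor and one hydrogen-bond acceptor, gives way to a 3-methylphenyl that carries neither. The measured data therefore give no guide to the size or direction of this step, and the estimate must be wide. Compound 4 is expected to come in around 40 nM, somewhere between 8 nM and 250 nM. For compound 4 this means an expected step of a 2.5-fold higher number from compound 1 to compound 4 (0.40 log units; beyond the scatter).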

Compound 4, half-maximal inhibitory concentration: 160 nM
Beside the measured number, compound 4's estimate is 4.0-fold (0.60 log units) below it; the range from low to high includes it.
By their numbers in this assay, from the lowest: compounds 2, 1 and 3 (each within the scatter of the next); then compound 4.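

Among the compounds shown, the halogen exchanges left the numbers in this assay within the scatter, whereas this change at the position on the ring with 1 nitrogen moves the number beyond it, a 10-fold higher number from compound 1 to compound 4 (1.00 log units; beyond the scatter) in size. What sits at this position therefore matters in a way the halogen swaps on the methoxy-bearing ring did not reveal, although compound 4 still gives 160 nM, so inhibition in this assay does not depend entirely on the carbamoyl. Nothing measured here explains why the number rises, and the change removes the carbamoyl's hydrogen-bond donor and acceptor while also adding a six-membered aromatic ring, so the two cannot be separated.

A plain phenyl would show what the methyl contributes, while an amine or a carboxylic acid at the same position would show whether a small group with hydrogen-bond donors or acceptors can hold the number near that of compound 1. From the compounds shown here alone, whether the halogens would remain indistinguishable with the 3-methylphenyl in place also remains open.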